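Amino acid amide variation on the shared core

The source may report more compounds than this note shows. Statements on the series, on what has been measured and on what is new or still open speak of the compounds shown alone.

Measured compounds:
compound 1 `O=C(O)[C@@H]1CCCN1C(=O)CN(c1nc(Cl)nc2[nH]cnc12)C1CC1` gives 31.5%
compound 2 `O=C(O)CC[C@H](NC(=O)CN(c1nc(Cl)nc2[nH]cnc12)C1CC1)C(=O)O` gives 26.8%
compound 3 `CC(C)[C@H](NC(=O)CN(c1nc(Cl)nc2[nH]cnc12)C1CC1)C(=O)O` gives 31.2%

In a functional assay on the whole organism (Tail, strain ICR) with Mus musculus as the target, in the tail flick test, with a stated time of 30 min, at a dose of 25 umol/kg by the oral route (a lower number here means a weaker effect, a higher number a stronger effect of the compound at the dose given), compound 3 stands second highest of the three values, but no value here is separated from another beyond the scatter: a number 0.3 percentage points lower from compound 1 to compound 3 (within the scatter) and a number 4.4 percentage points higher from compound 2 to compound 3 (within the scatter) are both within it. Compound 4 `O=C(O)CNC(=O)CN(c1nc(Cl)nc2[nH]cnc12)C1CC1` is the next variant of compound 3: hydrogen in place of isopropyl on a saturated chain carbon bound to an amide-type nitrogen and a carbonyl carbon. Among the measured compounds shown here, the only steps that bear on this change are those two, which vary the amino acid part or the group on the same saturated chain carbon, and both are small. The estimated step of a number 1.2 percentage points lower from compound 3 to compound 4 (within the scatter) is therefore expected to stay within the scatter, with no direction beyond it. Compound 4 is expected to give 30%, in a range from 20% to 40%.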

Compound 4, a percentage reported as activity, at one dose (the size of the read-out at that dose, not a potency): 32.2%
Compound 4: the middle estimate sits 2.2 percentage points below what was measured, within the range that was stated.
By their numbers in this assay, from the lowest: compounds 2, 3, 1 and 4 (each within the scatter of the next).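

In this assay hydrogen in place of isopropyl on this saturated chain carbon gives a number 1 percentage points higher from compound 3 to compound 4 (within the scatter) with no side chain left at this position. Hydrogen in place of 2-carboxyethyl gives a number 5.4 percentage points higher from compound 2 to compound 4 (within the scatter) and (carboxymethyl)amino in place of 2-carboxypyrrolidin-1-yl gives a number 0.7 percentage points higher from compound 1 to compound 4 (within the scatter) in the same test, so the read-out at this dose does not depend on the side chain in these steps. Nothing available accounts for this flat read-out. Open, on these data alone, is whether a primary amine or a longer alkyl chain on this carbon, or a methyl ester in place of the carboxylic acid, would move the read-out beyond the scatter.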